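Amide substituent series on the shared hexafluoro-carbinol core

The source may hold more compounds than are shown below. What is called first, only, known or untested is meant among the compounds shown, and "the series" means these compounds.

Measured compounds:
- compound 1 `O=C(COc1ccc2cc(C(O)(C(F)(F)F)C(F)(F)F)c(O)cc2c1)Nc1ccccc1`: > 20000 nM (a limit, not a number)
- compound 2 `O=C(COc1ccc2cc(C(O)(C(F)(F)F)C(F)(F)F)c(O)cc2c1)NCc1ccccc1`: > 20000 nM (a limit, not a number)
- compound 3 `O=C(COc1ccc2cc(C(O)(C(F)(F)F)C(F)(F)F)c(O)cc2c1)Nc1ccc(-c2ccccc2)cc1`: 3400 nM

Going by the values given here, in an assay on isolated protein for inhibition of receptor-type tyrosine-protein phosphatase C (Homo sapiens), read by spectrophotometry (a higher number here means a weaker inhibitor, a lower number a stronger inhibitor), compound 3 stands as the only compound with a measured number; the other two values are limits of the assay. The step of an at least 5.8-fold lower number from compound 1 to compound 3 (0.76 log units; beyond the scatter) and the step of an at least 5.8-fold lower number from compound 2 to compound 3 (0.76 log units; beyond the scatter) both run beyond the scatter toward compound 3. The step that the two limits leave unreadable from compound 1 to compound 2 cannot be read, because the limit of > 20000 nM in this assay, at which 2 of the 3 values shown sit, holds both ends.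

Compound 4 `O=C(COc1ccc2cc(C(O)(C(F)(F)F)C(F)(F)F)c(O)cc2c1)NC1CC1` is not yet measured. Its change from compound 3: cyclopropyl in place of 4-phenylphenyl on an amide-type nitrogen. The two readable steps both show that the 4-phenylphenyl group goes with the lower number, while phenyl and benzyl on the same nitrogen sit at the limit. Cyclopropyl is smaller still than phenyl or benzyl, so on this series a step back up in this assay is expected, of a size at least matching an at least 5.8-fold lower number from compound 1 to compound 3 (0.76 log units; beyond the scatter) in the reverse direction, and most likely a return to the limit.

Compound 4 is therefore estimated at 30000 nM in this assay, within 10000 nM to 100000 nM, meaning an expected step of an 8.8-fold higher number from compound 3 to compound 4 (0.95 log units; beyond the scatter).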

Compound 4, half-maximal inhibitory concentration: > 20000 nM
Compound 4: only a limit was reported; the forecaster's own chance of this, stated with the estimate: 75%; the middle value lies beyond the limit too.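

Cyclopropyl on the amide-type nitrogen does not keep what 4-phenylphenyl gave in this assay, with the change giving an at least 5.8-fold higher number from compound 3 to compound 4 (0.76 log units; beyond the scatter). Compound 4 gives > 20000 nM, a limit and not a number, so a third group on this nitrogen, and the first without an aromatic ring, joins phenyl and benzyl there, leaving compound 3 as the only one of the four with a number. The steps from compound 1 and from compound 2 to compound 4 cannot be read, and no order among phenyl, benzyl and cyclopropyl can be given, because all three stand at one limit: the limit of > 20000 nM in this assay, at which 3 of the 4 values shown sit.

The compounds shown leave open whether a longer alkyl chain on the same nitrogen would also give a number, or whether 4-phenylphenyl is needed in full. Also open, on these data alone, is how a carboxylic acid or an amine carried on the 4-phenylphenyl group would read in this assay.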